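The source may report more compounds than this note shows. Statements on the series, on what has been measured and on what is new or still open speak of the compounds shown alone.

Of the compounds shown here, three built on a shared core have been measured in an assay on isolated protein for agonist activity at Bile acid receptor (Homo sapiens), read by FRET; a higher number here means that more compound is needed for the effect, a lower number that less compound is needed. Compound 1 `CC(C)c1onc(-c2c(Cl)cccc2Cl)c1COc1ccc(NC(=O)c2ccc(C(=O)O)cc2)c(C(F)(F)F)n1` gives 452 nM, compound 2 `CCN(Cc1ccc(C(=O)O)cc1)c1ccc(OCc2c(-c3c(Cl)cccc3Cl)noc2C2CC2)nc1C(F)(F)F` gives 194 nM, and compound 3 `CC(c1ccc(OCc2c(-c3c(Cl)cccc3Cl)noc2C2CC2)nc1C(F)(F)F)N(C)c1ccc(C(=O)O)cc1` gives 179 nM. Compound 3 has the lowest of these three numbers; its value and that of compound 2 lie within the usual scatter of each other, while compound 1 has a clearly higher number. Compound 4 `CC(Oc1cccc(C(=O)O)c1)c1ccc(OCc2c(-c3c(Cl)cccc3Cl)noc2C2CC2)nc1C(F)(F)F` differs from compound 3 in one place: 3-carboxyphenoxy in place of (4-carboxyphenyl)(methyl)amino on a saturated chain carbon bound to an aromatic carbon and a saturated chain carbon. For the measured compounds named here, no measured pair shows this change, so no step size is known for it. In this assay the expected step is a 2.2-fold higher number from compound 3 to compound 4 (0.35 log units; beyond the scatter), a moderate move toward a higher number. Compound 4 is therefore expected to give about 400 nM, within the range 120 nM to 1500 nM.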

Compound 4, half-maximal effective concentration: 155 nM
Estimate against measurement, compound 4: 2.6-fold (0.41 log units) above; the range from low to high includes it.
By their numbers in this assay, from the lowest: compounds 4, 3 and 2 (each within the scatter of the next); then compound 1.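

Putting 3-carboxyphenoxy in place of (4-carboxyphenyl)(methyl)amino on this saturated chain carbon gives a 1.2-fold lower number from compound 3 to compound 4 (0.06 log units; within the scatter) in this assay, so the position accepts this exchange without a clear shift in the number. The two groups differ in more than one respect, as their names show, yet this read-out does not separate them.

On these data alone, a 4-carboxyphenoxy group would show whether the linking oxygen or the place of the carboxylic acid on the ring matters more, and a nitrile in place of that acid remains open too. No measurement here explains the result.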